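A few compounds are considered here, and "the series" means these few. Any claim that something is new, unique, unknown or untested is made for them only; others in the source may bear on it.

Compound 3, `CC(C)=CCC/C(C)=C/CC1Cc2c(OCCCNC(=O)c3cccs3)cc(=O)n(CCCO)c2CC1(C)C`, gives 72.8% in a functional assay on PANC-1 cells (Homo sapiens) for inhibition, read by MTT assay, with a stated time of 24 h, tested at 10 uM (on this read-out higher numbers stand for more inhibition at the one concentration tested (going by the name of the read-out) and lower numbers for less inhibition), the highest of the three numbers measured. Compound 1, `CC(C)=CCC1Cc2c(OCCCNC(=O)c3ccc([N+](=O)[O-])cc3)cc(=O)n(CCCO)c2CC1(C)C`, gives 49.9% in this assay, and compound 2, `COc1ccc(C(=O)NCCCOc2cc(=O)n(CCCO)c3c2CC(C/C=C(\C)CCC=C(C)C)C(C)(C)C3)cc1`, gives 45.7%; both gaps to compound 3 lie beyond the scatter. Compound 4, `CC(C)=CCC/C(C)=C/CC1Cc2c(OCCCNC(=O)c3ccc([N+](=O)[O-])cc3)cc(=O)n(CCCO)c2CC1(C)C`, is not yet measured. Its difference from compound 3 is 4-nitrophenyl in place of thiophen-2-yl on a carbonyl carbon.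

Going by the values given here, the one measured step that touches the group on the carbonyl carbon is a number 27.1 percentage points higher from compound 2 to compound 3 (beyond the scatter): replacing an aryl group with thiophen-2-yl raised the number well beyond the scatter. Compound 4 goes the other way, exchanging thiophen-2-yl for an aryl group, so a drop is the likelier outcome. Among the compounds with values here, compound 1, which carries the same 4-nitrophenyl group but a shorter chain on the shared core, sits well below compound 3, which points the same way, though no single step links compounds 1 and 4.

Compound 4 is therefore expected to give about 52% in this assay, likely between 38% and 66%, with the estimated step of a number 20.8 percentage points lower from compound 3 to compound 4 (beyond the scatter).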

Compound 4, a percentage reported as inhibition, at one concentration (the size of the read-out at that concentration, not a potency): 16.8%
Estimate against measurement, compound 4: 35.2 percentage points above; the whole stated range lies above it.
By their numbers in this assay, from the lowest: compound 4; then compounds 2 and 1 (each within the scatter of the next); then compound 3.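

In this assay, 4-nitrophenyl in place of thiophen-2-yl on the carbonyl carbon gives a number 56 percentage points lower from compound 3 to compound 4 (beyond the scatter), so this position is sensitive to more than the swap of a five-membered ring for a six-membered one: with nitro in place of methoxy on an aromatic carbon, the two phenyl-bearing compounds also part, with a number 28.9 percentage points lower from compound 2 to compound 4 (beyond the scatter). The chain on the shared core matters too, since 3-methylbut-2-en-1-yl in place of hydrogen on a saturated chain carbon bound to a double-bonded chain carbon gives a number 33.1 percentage points lower from compound 1 to compound 4 (beyond the scatter). Nothing at hand explains either drop.

The compounds shown leave open how an unsubstituted phenyl or a furan-2-yl group would read on the carbonyl carbon. They also leave open whether the longer chain would lower the number in the same way with thiophen-2-yl on the carbonyl carbon.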